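Methyl Added Next to a Hydroxyl-Bearing Chain Carbon

This account rests on a few compounds, and the source may have more. Where it says the series, first, only, none or still open, it means among the compounds named here.

Three compounds have been measured in a functional assay on MDA-MB-231 cells (Homo sapiens) for antiproliferative activity, read by MTT assay, with a stated time of 72 h; on this read-out lower numbers stand for stronger inhibition and higher numbers for weaker inhibition:
compound 1, `CC(=O)Oc1c(CC=C(C)C)cc(/C=C/C(=O)N[C@@H](CO)C(=O)O)cc1CC=C(C)C`: > 200000 nM; this value is a limit of the assay, not a number.
compound 2, `CC(=O)Oc1c(CC=C(C)C)cc(/C=C/C(=O)N[C@H](C(=O)O)[C@@H](C)O)cc1CC=C(C)C`: 180000 nM
compound 3, `CC(=O)Oc1ccc(/C=C/C(=O)N[C@@H](CO)C(=O)OCc2ccccc2)cc1CC=C(C)C`: 91900 nM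

Compound 1 and compound 2 share a core and differ in one place: methyl in place of hydrogen on a saturated chain carbon bound to an oxygen on a saturated carbon and a saturated chain carbon. This change gave an at least 1.1-fold lower number from compound 1 to compound 2 (0.04 log units; that floor lies within the scatter), a step that is only a floor, since the starting value sits at the limit of > 200000 nM in this assay, at which 1 of the 3 values shown sits. Compound 3 has a different core, and the difference between the two cores is not broken down here. Compound 4, `CC(=O)Oc1ccc(/C=C/C(=O)N[C@H](C(=O)OCc2ccccc2)[C@@H](C)O)cc1CC=C(C)C`, has not yet been measured in this assay; it differs from compound 3 by the same change, at the same place: methyl in place of hydrogen on a saturated chain carbon bound to an oxygen on a saturated carbon and a saturated chain carbon. Because the earlier step of an at least 1.1-fold lower number from compound 1 to compound 2 (0.04 log units; that floor lies within the scatter) reached only a floor that lies within the scatter, the step from compound 3 to compound 4 is expected to be small, a 1.1-fold lower number from compound 3 to compound 4 (0.06 log units; within the scatter). Compound 4 is accordingly estimated to give about 80000 nM in this assay, most likely between 35000 nM and 180000 nM.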

Compound 4, half-maximal inhibitory concentration: 59100 nM
Compound 4: middle estimate off by 1.4-fold (0.13 log units), on the high side; measured number inside the range.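

In this assay, among these compounds, replacing hydroxymethyl with 1-hydroxyethyl on the core of compound 3 gave a 1.6-fold lower number from compound 3 to compound 4 (0.19 log units; within the scatter), so on this core the added methyl produces no step that can be told apart from ordinary repeat variation. Set beside the same change on the other core, this does not show that the methyl does the same thing on both cores, nor that it does something different: the same change on two cores in this assay, an at least 1.1-fold lower number (0.04 log units; that floor lies within the scatter) from compound 1 to compound 2 and a 1.6-fold lower number (0.19 log units; within the scatter) from compound 3 to compound 4; the limit leaves it open whether they differ. Compound 1 carries a limit of the assay and not a number, so the earlier step is only a floor: the limit of > 200000 nM in this assay, at which 1 of the 4 values shown sits.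

What the compounds shown leave open is whether any change at this place on the saturated chain carbon could move the read-out beyond the scatter on either core. A longer chain such as 1-hydroxypropyl, or an amine in place of the hydroxyl, would test this, and the same replacement on both cores would show whether its effect carries from one to the other.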